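This account rests on a few compounds, and the source may have more. Where it says the series, first, only, none or still open, it means among the compounds named here.

Series notes. Compound 2, `COc1ccc(-c2cc(-c3ccccc3-c3ccccc3)n[nH]2)cc1`, is the lower of the two numbers recorded so far in a functional assay on AGS cells (Homo sapiens) for inhibition, read by MTT assay, with a stated time of 48 h; on this read-out higher numbers stand for weaker inhibition of growth and lower numbers for stronger inhibition of growth: compound 2 gives 790 nM, while compound 1, `COc1ccc(-c2cc(-c3ccccc3)n[nH]2)cc1`, gives 11300 nM. For the measured compounds named here, the only measured step, a 14-fold lower number from compound 1 to compound 2 (1.16 log units; beyond the scatter), concerns a phenyl in place of hydrogen on an aromatic carbon and says nothing about the substituent on the other ring.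

Compound 3, `FC(F)(F)c1ccc(-c2cc(-c3ccccc3-c3ccccc3)n[nH]2)cc1`, is not yet measured. It differs from compound 2 by trifluoromethyl in place of methoxy on an aromatic carbon, on an aromatic carbon of a six-membered aromatic ring of carbon only, para to a large group. Going by the values given here, no recorded step bears on this exchange, so the expectation rests on compound 2 alone. The estimated change is a 1.0-fold higher number from compound 2 to compound 3 (0.01 log units; within the scatter), with no direction expected beyond the scatter. Compound 3 is therefore expected to give about 800 nM, within 300 nM to 2500 nM.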

Compound 3, concentration for 50% growth inhibition: 6900 nM
For compound 3 the middle estimate is 8.6-fold (0.94 log units) below the measured one, outside the stated range (above it).
By their numbers in this assay, from the lowest: compound 2; then compounds 3 and 1 (each within the scatter of the next).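

Series notes, continued. The substituent at this position is now shown to matter: on an aromatic carbon para to a large group, with the rest of compound 2 kept, trifluoromethyl in place of methoxy gives an 8.7-fold higher number from compound 2 to compound 3 (0.94 log units; beyond the scatter) in this assay. Of the two groups seen here, methoxy therefore goes with the stronger inhibition of growth, so the earlier gain from the added phenyl does not hold regardless of what this position carries. No supporting data on any property of these compounds are available to explain the step.

For the compounds shown here, with only two groups at this position, it remains open whether the step follows from losing methoxy or from gaining trifluoromethyl, and a hydroxyl, a chlorine or an amine here would help separate the two. Also open, on these data alone, is whether the same exchange gives a similar step on the core of compound 1, without the added phenyl.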